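The compounds below may be only part of what the source reports. "The series", "measured", "known", "first", "only" and "open" are said of these compounds alone.

Working notes on the series. Compound 1 `COc1ccc(Cl)cc1C(=O)NCCC1CCN(S(=O)(=O)NC(=O)NC2CCCCC2)CC1`, compound 2 `COc1ccc(NC(=O)NS(=O)(=O)N2CCC(CCNC(=O)c3cc(Cl)ccc3OC)CC2)cc1` and compound 3 `COc1ccc(Cl)cc1C(=O)NCCC1CCN(S(=O)(=O)NC(=O)NC[C@@H]2C[C@@H]3CC[C@@H]2O3)CC1` share one core and differ only in the group on the amide-type nitrogen. In a functional assay on the whole organism (blood) with Rattus norvegicus as the target, with stated times of 24 h and 1 h, at a dose of 5 mg/kg by the intraperitoneal route (on this read-out lower numbers stand for a weaker effect and higher numbers for a stronger effect at the one dose given), compound 1 gives 25%, compound 2 gives 27% and compound 3 gives 30%. Compound 3 holds the highest of the three numbers, but every gap lies within the scatter: a number 2 percentage points higher from compound 1 to compound 2 (within the scatter), a number 5 percentage points higher from compound 1 to compound 3 (within the scatter), a number 3 percentage points higher from compound 2 to compound 3 (within the scatter). Compound 4 `COc1ncccc1C(=O)NCCC1CCN(S(=O)(=O)NC(=O)NC[C@@H]2C[C@@H]3CC[C@@H]2O3)CC1` carries 2-methoxypyridin-3-yl in place of 5-chloro-2-methoxyphenyl on a carbonyl carbon. Among the compounds with values here, no measured step touches this part of the molecule, so none bears directly on it; the three steps at the amide-type nitrogen all stayed within the scatter. For compound 4 a step of no change at the digits printed from compound 3 to compound 4 (within the scatter) is expected, nothing beyond the scatter. The estimate for compound 4 in this assay is 30%, within 15% to 45%.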

Compound 4, a percentage reported as activity, at one dose (the size of the read-out at that dose, not a potency): 34%
For compound 4 the middle estimate is 4 percentage points below the measured one; the measured number falls inside the stated range.
By their numbers in this assay, from the lowest: compounds 1, 2, 3 and 4 (each within the scatter of the next).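

Within the data shown here, the only step at this carbonyl carbon, 2-methoxypyridin-3-yl in place of 5-chloro-2-methoxyphenyl, reads as a number 4 percentage points higher from compound 3 to compound 4 (within the scatter) in this assay. At this position, then, the chlorine-bearing carbon ring can give way to a ring with one hetero atom without a step beyond the scatter. No available evidence bears on this result. Still open, as far as these compounds go, is whether an amine or a carboxylic acid on this aromatic ring would move the number beyond the scatter. Also open, from the compounds shown here alone, is whether the same exchange gives a similar step with cyclohexyl on the amide-type nitrogen.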